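Aryl hydrazone swap: dimethylphenyl gives way to chloro-nitrophenyl

This account rests on a few compounds, and the source may have more. Where it says the series, first, only, none or still open, it means among the compounds named here.

Compound 1, `Cn1c(=O)c(=O)n(C2CCCC2)c2nc(N/N=C/c3ccc(O)cc3)ncc21`, in a functional assay on PC-3 cells (Homo sapiens) for antiproliferative activity, read by MTT assay; a lower number here means a stronger inhibitor, a higher number a weaker inhibitor: > 100000 nM, a limit of the assay rather than a number.
Compound 2, `Cc1cccc(/C=N/Nc2ncc3c(n2)n(C2CCCC2)c(=O)c(=O)n3C)c1`, in this assay: 53600 nM.
Compound 3, `Cc1ccc(/C=N/Nc2ncc3c(n2)n(C2CCCC2)c(=O)c(=O)n3C)cc1C`, in this assay: 39000 nM.

Compound 3 holds the lowest of the two numbers, yet a 1.4-fold lower number from compound 2 to compound 3 (0.14 log units; within the scatter), so it cannot be called the more potent of the pair. Compound 1 gave only a limit, (the limit of > 100000 nM in this assay, at which 1 of the 3 values shown sits). The three differ in the aryl group hung on the hydrazone carbon: an at least 1.8-fold lower number from compound 1 to compound 2 (0.27 log units; that floor lies within the scatter) and an at least 2.5-fold lower number from compound 1 to compound 3 (0.40 log units; beyond the scatter), so leaving the 4-hydroxyphenyl behind gave lower numbers, although only the second of these steps goes beyond the scatter.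

Compound 4, `Cn1c(=O)c(=O)n(C2CCCC2)c2nc(N/N=C/c3cc([N+](=O)[O-])ccc3Cl)ncc21`, carries yet another aryl group at that position: 2-chloro-5-nitrophenyl in place of 3,4-dimethylphenyl on a carbon with a double bond to nitrogen. Within the data shown here, no measured step introduces a chlorine or a nitro group, so the measured steps bear on it only indirectly: they show that the aryl group can move the number, by an at least 2.5-fold lower number from compound 1 to compound 3 (0.40 log units; beyond the scatter), and that adding a methyl to it changed little, by a 1.4-fold lower number from compound 2 to compound 3 (0.14 log units; within the scatter). The expected outcome is therefore a 1.0-fold higher number from compound 3 to compound 4 (0.01 log units; within the scatter), a step that need not go beyond the scatter in either direction. Compound 4 is estimated at 40000 nM, with a range from 12000 nM to 100000 nM.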

Compound 4, half-maximal inhibitory concentration: 9260 nM
Compound 4: the middle estimate sits 4.3-fold (0.64 log units) above what was measured; the measured number lies below the stated range.
By their numbers in this assay, from the lowest: compound 4; then compounds 3 and 2 (each within the scatter of the next). At a limit, above all of these: compound 1.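

Among the earlier compounds with a real number, the aryl group on a carbon with a double bond to nitrogen had produced no gap beyond the scatter, since compounds 2 and 3 sit within it of each other; 2-chloro-5-nitrophenyl now opens such a gap in this assay, with a 4.2-fold lower number from compound 3 to compound 4 (0.62 log units; beyond the scatter) and a 5.8-fold lower number from compound 2 to compound 4 (0.76 log units; beyond the scatter). Measured against the 4-hydroxyphenyl group, the same change gives an at least 10-fold lower number from compound 1 to compound 4 (1.03 log units; beyond the scatter), so every step to compound 4 lies beyond the scatter and compound 4 is the strongest of the four in this read-out. That last step starts from a limit of the assay and not from a number: the limit of > 100000 nM in this assay, at which 1 of the 4 values shown sits.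

Because chloro and nitro enter together, the compounds shown cannot tell whether one of them alone would give the same drop, or whether both are needed. Also open, going by these compounds, is what an amine or a carboxylic acid on this aryl group would do to the number, and whether a phenyl group carrying chloro and nitro in other places would behave like 2-chloro-5-nitrophenyl.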